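This account rests on a few compounds, and the source may have more. Where it says the series, first, only, none or still open, it means among the compounds named here.

Of the compounds shown here, three built on one shared core have been tested in a functional assay on MKN-45 cells (Homo sapiens) for cytotoxicity, read by MTT assay, with a stated time of 72 h; on this read-out higher numbers stand for weaker inhibition and lower numbers for stronger inhibition. Compound 1 `CN(C)CCNc1nc(-c2ccc(NC(=O)Nc3ccc(F)cc3)cc2)nc2ccsc12` gives 330 nM. Compound 2 `CN(C)CCNc1nc(-c2ccc(NC(=O)Nc3ccccc3F)cc2)nc2ccsc12` gives 530 nM, and compound 3 `CN(C)CCNc1nc(-c2ccc(NC(=O)Nc3ccccc3Cl)cc2)nc2ccsc12` gives 850 nM. Compound 3 thus holds the highest of the three numbers, although its nearest neighbour is compound 2, with a 1.6-fold higher number from compound 2 to compound 3 (0.21 log units; within the scatter) staying within the scatter, while a 2.6-fold higher number from compound 1 to compound 3 (0.41 log units; beyond the scatter) lies beyond it. Compound 4 `Cc1ccc(NC(=O)Nc2ccc(-c3nc(NCCN(C)C)c4sccc4n3)cc2)cc1` differs from compound 3 in one place: 4-methylphenyl in place of 2-chlorophenyl on an amide-type nitrogen. Two measured steps speak to this change. The exchange of chloro for fluoro, a 1.6-fold higher number from compound 2 to compound 3 (0.21 log units; within the scatter), was small, whereas the move from 4-fluorophenyl to 2-chlorophenyl, a 2.6-fold higher number from compound 1 to compound 3 (0.41 log units; beyond the scatter), raised the number modestly. Compound 1, with 330 nM, carries its substituent in the same pattern as the 4-methylphenyl group entering here. For compound 4 the expected step is therefore a 2.4-fold lower number from compound 3 to compound 4 (0.39 log units; beyond the scatter), back toward lower numbers. Compound 4 is estimated at 350 nM in this assay, with a range from 150 nM to 900 nM.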

Compound 4, half-maximal inhibitory concentration: 2380 nM
Compound 4: middle estimate off by 6.8-fold (0.83 log units), on the low side; the measured number lies above the stated range.
By their numbers in this assay, from the lowest: compounds 1, 2 and 3 (each within the scatter of the next, the first and the last beyond it); then compound 4.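

At this amide-type nitrogen, the substituent itself matters and not only its pattern on the phenyl ring: in this assay, exchanging the fluoro group for a methyl group gives the largest step of the set (a 7.2-fold higher number from compound 1 to compound 4 (0.86 log units; beyond the scatter)). The 4-methylphenyl group therefore does not follow 4-fluorophenyl toward a low number, and it also falls behind 2-chlorophenyl (a 2.8-fold higher number from compound 3 to compound 4 (0.45 log units; beyond the scatter)) and 2-fluorophenyl (a 4.5-fold higher number from compound 2 to compound 4 (0.65 log units; beyond the scatter)). All three steps lie beyond the scatter, so compound 4 holds the highest number of the four.

As far as these compounds go, whether an unsubstituted phenyl, 4-chlorophenyl or 4-methoxyphenyl group would sit nearer compound 1 or compound 4 remains open. No supporting measurement is available to explain the difference between the fluoro and methyl groups at this position.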